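Replacing methoxy in a series held at its limit

The source may hold more compounds than are shown below. What is called first, only, known or untested is meant among the compounds shown, and "the series" means these compounds.

In a functional assay on Raji cells (Homo sapiens) for cytotoxicity, with a stated time of 72 h (on this read-out higher numbers stand for an effect only at larger amounts of compound and lower numbers for an effect already at smaller amounts), compound 1 (`C=C[C@@](C)(/C=C/c1ccc(OC)cc1)CCC=C(C)C`) gives > 26000 nM as a limit of the assay and not a number. Compound 2 (`C=C[C@@](C)(/C=C/c1ccc(O)cc1)CC/C=C/C(=O)c1ccccc1`) also gives > 26000 nM as a limit. Compound 3 (`COc1ccc(/C=C/[C@@](C)(/C=C/c2ccc(O)c(/C=C/C(=O)c3ccccc3)c2)CCC=C(C)C)cc1`) likewise gives > 26000 nM as a limit. Compound 1 therefore stands with the other two measured compounds at the limit of > 26000 nM in this assay, at which 3 of the 3 values shown sit, and has no numerical position within the series.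

Compound 4 (`C=C[C@@](C)(/C=C/c1ccc(Nc2cc(F)cc(F)c2)cc1)CCC=C(C)C`) has (3,5-difluorophenyl)amino in place of methoxy on an aromatic carbon, para to a large group ((3,5-difluorophenyl)amino in place of methoxy on an aromatic carbon). The entering group brings a six-membered aromatic ring of carbon only.

Within the data shown here, the series offers no measured step to scale from. In this assay a modest move toward lower numbers is expected at best, and a result that remains a limit would be no surprise. This caution rests on compound 1, whose > 26000 nM is a limit. The expected size is an at least 1.4-fold lower number from compound 1 to compound 4 (0.15 log units; that floor lies within the scatter) as an estimate, and the true step may be larger since the starting point is not a number. Compound 4 is expected at 18000 nM with an estimated range from 6000 nM to 30000 nM in this read-out.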

Compound 4, half-maximal effective concentration: > 26000 nM
Compound 4: only a limit was reported (the forecaster's own chance of this, stated with the estimate: 55%); at least 1.4-fold (0.15 log units) between middle value and limit.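

In this assay compound 4 gives > 26000 nM, a limit of the assay and not a number. No step can be read from compound 1 to compound 4, as both stand at the same limit: the limit of > 26000 nM in this assay, at which 4 of the 4 values shown sit.

The compounds shown leave open whether any replacement of methoxy yields a numerical value, and how these compounds rank against one another.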